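Methoxy Additions on Two Related Chalcone Cores

The source may report more compounds than this note shows. Statements on the series, on what has been measured and on what is new or still open speak of the compounds shown alone.

Measured in a functional assay on HeLa cells (Homo sapiens) for inhibition, read by MTT assay, with a stated time of 72 h; on this read-out lower numbers stand for stronger inhibition and higher numbers for weaker inhibition:
compound 1 `COc1cc(O)cc(O)c1C(=O)/C=C/c1ccc(O)cc1` – 48100 nM
compound 2 `COc1cc(/C=C/C(=O)c2c(O)cc(O)cc2OC)ccc1O` – > 50000 nM, a limit of the assay
compound 3 `COc1cc(/C=C/C(=O)c2c(O)cc(O)cc2OC)cc(OC)c1` – 13300 nM

In this assay compound 1 gives 48100 nM. For compound 2 this assay reports only a limit, > 50000 nM. The change between them is methoxy in place of hydrogen on an aromatic carbon, and it makes an at least 1.0-fold higher number from compound 1 to compound 2 (0.01 log units; that floor lies within the scatter), a step that rests on (the limit of > 50000 nM in this assay, at which 1 of the 3 values shown sits). Compound 3 gives 13300 nM in this assay, the lowest of the two measured numbers; how its core differs from that of compound 1 is not broken down here.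

Compound 4 `COc1cc(/C=C/C(=O)c2c(O)cc(O)cc2OC)cc(OC)c1OC` differs from compound 3 by methoxy in place of hydrogen on an aromatic carbon. It is the same kind of change as from compound 1 to compound 2, but the place differs: there the carbon was ortho to a hydroxy group and meta to a large group, here it is ortho to two methoxy groups and para to a large group. With only the earlier step, which reached a limit, as a guide, the expected step is a 1.3-fold lower number from compound 3 to compound 4 (0.12 log units; within the scatter). Compound 4 is therefore estimated at 10000 nM in this assay, between 3000 nM and 40000 nM.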

Compound 4, half-maximal inhibitory concentration: 18900 nM
For compound 4 the middle estimate is 1.9-fold (0.28 log units) below the measured one; the range from low to high includes it.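

In this assay methoxy in place of hydrogen on an aromatic carbon gives a 1.4-fold higher number from compound 3 to compound 4 (0.15 log units; within the scatter) on this core. Going by these compounds, compound 2 gives > 50000 nM in this assay, which is a limit of the assay and not a number, so the earlier step has only a floor and the size of the change on the core of compound 1 stays unknown. The data therefore neither show that the change carries over from one core to the other nor show that it does not: the same change on two cores in this assay, an at least 1.0-fold higher number (0.01 log units; that floor lies within the scatter) from compound 1 to compound 2 and a 1.4-fold higher number (0.15 log units; within the scatter) from compound 3 to compound 4; the limit leaves it open whether they differ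

The compounds shown leave open how an amine or a carboxylic acid would read at the carbon that carries the new methoxy in compound 4. They also leave open whether a longer chain, such as ethoxy, would read differently there.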